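The source may report more compounds than this note shows. Statements on the series, on what has been measured and on what is new or still open speak of the compounds shown alone.

Measured so far in a functional assay on U-937 cells (Homo sapiens) for cytotoxicity, read by MTT assay, with a stated time of 3 days; on this read-out higher numbers stand for weaker inhibition and lower numbers for stronger inhibition:
- compound 1 `N#Cc1c(Nc2ccccc2)nc(SCc2nc3ccccc3[nH]2)nc1-c1ccccc1` gives 3.28 nM
- compound 2 `CCNc1nc(SCc2nc3ccccc3[nH]2)nc(-c2ccccc2)c1C#N` gives 2.63 nM
- compound 3 `N#Cc1c(-c2ccccc2)nc(SCc2nc3ccccc3[nH]2)nc1N1CCNCC1` gives 5.81 nM

Compound 3 stays within the scatter of compound 1 (a 1.8-fold higher number from compound 1 to compound 3 (0.25 log units; within the scatter)) and lies beyond it only against compound 2 (a 2.2-fold higher number from compound 2 to compound 3 (0.34 log units; beyond the scatter)), a modest gap.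

The next step leads to compound 4 `Cc1ccc(S(=O)(=O)N2CCN(c3nc(SCc4nc5ccccc5[nH]4)nc(-c4ccccc4)c3C#N)CC2)cc1`, not yet measured. The change ((4-methylphenyl)sulfonyl in place of hydrogen on an amine nitrogen in a ring) puts (4-methylphenyl)sulfonyl in place of hydrogen on an amine nitrogen in a ring, the six-membered non-aromatic ring with 2 nitrogen.

Among the measured compounds shown here, no measured step makes this exact change, so the evidence is indirect. The nearest steps swap the whole amine group on the shared core. Besides the two above, the step between the first two compounds is also small (a 1.2-fold lower number from compound 1 to compound 2 (0.10 log units; within the scatter)). Across these three compounds, the amine group has so far moved the number very little. Resting on the largest of these steps (a 2.2-fold higher number from compound 2 to compound 3 (0.34 log units; beyond the scatter)), no shift beyond the scatter is expected in this assay, in either direction. For the measured compounds named here, the range is kept wide, as the incoming group has no precedent.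

The expected step is small (a 1.2-fold lower number from compound 3 to compound 4 (0.07 log units; within the scatter)). The estimate for compound 4 is 5 nM (expected range 1.5 nM to 20 nM).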

Compound 4, half-maximal inhibitory concentration: 4.1 nM
Beside the measured number, compound 4's estimate is 1.2-fold (0.09 log units) above it; measured number inside the range.
By their numbers in this assay, from the lowest: compounds 2, 1, 4 and 3 (each within the scatter of the next, the first and the last beyond it).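

Among the compounds shown here, the amine nitrogen in the six-membered non-aromatic ring of compound 3 had so far been seen only bearing hydrogen, and the earlier steps swapped the whole amine group on the shared core; this is the first change made on that ring itself. In this assay, (4-methylphenyl)sulfonyl enters there, bringing 10 heavy atoms and a six-membered aromatic ring of carbon only, and the number stays within the scatter (a 1.4-fold lower number from compound 3 to compound 4 (0.15 log units; within the scatter)), so a group of this size on this nitrogen leaves the read-out where it was. No measurement here bears on why the number holds with this group in place.

As far as these compounds go, it remains open whether the sulfonyl link or the 4-methylphenyl ring counts for more at this nitrogen: a methylsulfonyl group, a benzoyl group and a benzyl group on the same atom would separate the two. Also open, from the compounds shown here alone, is whether the number would hold with a carboxylic acid or a primary amine carried on a longer chain at this nitrogen.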